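A Hydroxyethyl Amide in Place of the Pyrazine Amide

The source may hold more compounds than are shown below. What is called first, only, known or untested is meant among the compounds shown, and "the series" means these compounds.

Among the measured compounds shown here, compound 2 `O=C(Nc1cccc(Nc2ncc(F)c(Nc3ccc(F)cc3)n2)c1)c1cnccn1` gives 10300 nM in a functional assay on A549 cells (Homo sapiens) for antiproliferative activity, read by sulforhodamine B assay, with a stated time of 3 days (on this read-out higher numbers stand for weaker inhibition of growth and lower numbers for stronger inhibition of growth), the only number among the values shown. Compound 1 `O=C(Nc1nccs1)c1cccc(Nc2ncc(F)c(Nc3ccc(F)cc3)n2)c1` reaches only a limit, > 10000 nM. The step that the limit leaves unreadable from compound 1 to compound 2 cannot be read because the limit of > 10000 nM in this assay, at which 1 of the 2 values shown sits, hides the value of compound 1. Compound 3 `O=C(NCCO)c1cccc(Nc2ncc(F)c(Nc3ccc(F)cc3)n2)c1` differs from compound 2 by (2-hydroxyethyl)carbamoyl in place of ((pyrazin-2-yl)carbonyl)amino on an aromatic carbon. For the measured compounds named here, no measured step bears on this change, so no step beyond the scatter is expected in this assay in either direction. Compound 3 is expected at 10000 nM, between 3000 nM and 30000 nM. The step of a 1.0-fold lower number from compound 2 to compound 3 (0.01 log units; within the scatter) is thus expected to be flat.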

Compound 3, concentration for 50% growth inhibition: 11900 nM
Compound 3: middle estimate off by 1.2-fold (0.08 log units), on the low side; low and high end bracket the measured number.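

In this assay, (2-hydroxyethyl)carbamoyl in place of ((pyrazin-2-yl)carbonyl)amino gives a 1.2-fold higher number from compound 2 to compound 3 (0.06 log units; within the scatter). At this place, on an aromatic carbon meta to a large group, a group with no ring and one with a six-membered aromatic ring therefore read alike. Compound 1 stands at a limit, so the steps from it cannot be read: the limit of > 10000 nM in this assay, at which 1 of the 3 values shown sits.

Nothing shown here yet gives a number clearly lower than these. From the compounds shown here alone, it stays open whether a basic amine or a carboxylic acid at this place would do so.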